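The source may hold more compounds than are shown below. What is called first, only, known or untested is meant among the compounds shown, and "the series" means these compounds.

In an ADME assay on the whole organism (Mus musculus, strain Swiss Webster) for pharmacokinetics, read by LC-MS, at a dose of 50 mg/kg by the oral route (a lower number here means less compound in the circulation, a higher number more compound in the circulation at the dose given), compound 1 `O=C(Nc1ccc(F)c(-c2nc3ncc(-c4ccc(F)c(F)c4)cc3[nH]2)c1)N1CCCC1` gives 6670 nM, a number within the scatter of both other measured compounds: compound 2 `O=C(Nc1ccc(F)c(-c2nc3ncc(-c4ccc(F)cc4F)cc3[nH]2)c1)N1CCCC1` gives 9500 nM, and compound 3 `O=C(Nc1ccc(F)c(-c2nc3ncc(-c4ccc(F)cc4)cc3[nH]2)c1)N1CCCC1` gives 6270 nM. Compound 4 `O=C(Nc1ccc(F)c(-c2nc3ncc(-c4cccc(F)c4F)cc3[nH]2)c1)N1CCCC1` is still unmeasured, and its difference from compound 1 is 2,3-difluorophenyl in place of 3,4-difluorophenyl on an aromatic carbon. Among the measured compounds shown here, three measured steps bear on this change. Exchanging 3,4-difluorophenyl for 2,4-difluorophenyl gave a 1.4-fold higher number from compound 1 to compound 2 (0.15 log units; within the scatter), while replacing a fluoro with hydrogen gave a 1.1-fold lower number from compound 1 to compound 3 (0.03 log units; within the scatter) and a 1.5-fold lower number from compound 2 to compound 3 (0.18 log units; within the scatter). All three lie within the scatter, so no step beyond the scatter is expected in this assay. The expected change is small, at a 1.1-fold higher number from compound 1 to compound 4 (0.05 log units; within the scatter). For compound 4, the estimated value is 7500 nM, with an expected range of 3700 nM to 15000 nM.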

Compound 4, maximal plasma concentration: 1830 nM
Estimate against measurement, compound 4: 4.1-fold (0.61 log units) above; the whole stated range lies above it.
By their numbers in this assay, from the lowest: compound 4; then compounds 3, 1 and 2 (each within the scatter of the next).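

In this assay the position proves sensitive to how the two fluorines are arranged, which compounds 1, 2 and 3 did not show, as they lay within the scatter of one another. The 2,3-difluorophenyl group gives a 3.6-fold lower number from compound 1 to compound 4 (0.56 log units; beyond the scatter) and a 5.2-fold lower number from compound 2 to compound 4 (0.72 log units; beyond the scatter) and also a 3.4-fold lower number from compound 3 to compound 4 (0.53 log units; beyond the scatter) with the same atom count as the other difluorophenyl groups. Nothing available explains this step.

Open, from the compounds shown here alone, is whether 2-fluorophenyl, 3-fluorophenyl or 2,6-difluorophenyl would group with compound 4 or with the other three. Also open, going by these compounds, is how a pyridine ring or an amine would behave here.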